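A few compounds are considered here, and "the series" means these few. Any claim that something is new, unique, unknown or untested is made for them only; others in the source may bear on it.

Measured compounds:
- compound 1, `COc1cc2cc(Oc3ccc(NC(=O)Nc4ccccc4)cc3)c(C)nc2cc1OC`, 54.1%
- compound 2, `COc1cc2cc(Oc3ccc(NC(=O)Nc4ccc(C)cc4)cc3)c(C)nc2cc1OC`, 107%
- compound 3, `COc1cc2cc(Oc3ccc(NC(=O)Nc4cccc(C(F)(F)F)c4)cc3)c(C)nc2cc1OC`, -15.1%

In a functional assay on SF-295 cells (Homo sapiens) for inhibition, read by sulforhodamine B assay, with a stated time of 48 h, tested at 10 uM (on this read-out higher numbers stand for a weaker effect at the one concentration tested and lower numbers for a stronger effect), compound 3 stands lowest of the three numbers. Its nearest neighbour is compound 1, from which a number 69.2 percentage points lower from compound 1 to compound 3 (beyond the scatter); the furthest is compound 2, from which a number 122.1 percentage points lower from compound 2 to compound 3 (beyond the scatter). The other measured step runs the opposite way: a number 52.9 percentage points higher from compound 1 to compound 2 (beyond the scatter).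

Compound 4, `COc1cc2cc(Oc3ccc(NC(=O)Nc4ccc(Cl)c(C(F)(F)F)c4)cc3)c(C)nc2cc1OC`, differs from compound 3 by chloro in place of hydrogen on an aromatic carbon.

Within the data shown here, none of the measured steps carries a chloro group, so no step bears directly on this change. The measured steps show that substituents on the terminal phenyl ring of the shared core move the read-out in this assay by large amounts in either direction, with compound 2 rising and compound 3 falling relative to compound 1. Compound 4 keeps the trifluoromethyl group of compound 3 and adds chloro beside nothing that has been tested. The expectation is therefore anchored on compound 3, with an added step that is estimated to be small and downward, or none beyond the scatter: a number 9.9 percentage points lower from compound 3 to compound 4 (within the scatter). Compound 4 is accordingly expected to give -25% in this assay, with a range from -65% to 15%.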

Compound 4, a percentage reported as activity, at one concentration (the size of the read-out at that concentration, not a potency): -70.9%
Compound 4: the middle estimate sits 45.9 percentage points above what was measured; measured number below the stated range.
By their numbers in this assay, from the lowest: compound 4; then compound 3; then compound 1; then compound 2.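

In this assay, chloro in place of hydrogen on an aromatic carbon, ortho to a trifluoromethyl group and para to a large group, gives a number 55.8 percentage points lower from compound 3 to compound 4 (beyond the scatter), which shows that this position on the terminal ring can still move the read-out strongly when the trifluoromethyl group is already present. The 4-chloro-3-(trifluoromethyl)phenyl group gives a number 125 percentage points lower from compound 1 to compound 4 (beyond the scatter) and a number 177.9 percentage points lower from compound 2 to compound 4 (beyond the scatter), the two widest steps in the set, and compound 4 stands lowest of the four compounds, beyond the scatter from each of the others. Nothing given here accounts for the size of the chloro step.

The compounds shown leave open whether chloro at this place would lower the number without the trifluoromethyl group, as it appears here only together with that group. They also leave open how a fluoro group, a methoxy group, a nitrile or an amine at the same place would compare with chloro on the 3-(trifluoromethyl)phenyl ring.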